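The source may hold more compounds than are shown below. What is called first, only, known or untested is meant among the compounds shown, and "the series" means these compounds.

Compound 1 `COc1ccc(/C=C\c2cc(OC)c(OC)c(OC)c2)cc1OCc1ccc(CN2CCCC[C@@H]2C(=O)O)cc1` and compound 2 `COc1ccc(/C=C\c2cc(OC)c(OC)c(OC)c2)cc1OCc1ccc(CN2CC[C@@H](O)C2)cc1` share one core and differ only in the group attached on a saturated chain carbon bound to an aromatic carbon. In a functional assay on MC-38 cells (Mus musculus) for antiproliferative activity, read by CCK-8 assay, with a stated time of 48 h (a higher number here means a weaker inhibitor, a lower number a stronger inhibitor), compound 1 gives only a limit, > 10000 nM, meaning that no number was reached (the limit of > 10000 nM in this assay, at which 1 of the 2 values shown sits). In this assay compound 2 gives 6900 nM. The step of an at least 1.4-fold lower number from compound 1 to compound 2 (0.16 log units; that floor lies within the scatter) is thus known only as a floor, and that floor lies within the scatter, so it does not establish a direction. Compound 3 `COc1ccc(/C=C\c2cc(OC)c(OC)c(OC)c2)cc1OCc1ccc(CN2CCCCC2C(=O)NCCN)cc1` is built on compound 1 with a single change: 2-((2-aminoethyl)carbamoyl)piperidin-1-yl in place of 2-carboxypiperidin-1-yl on a saturated chain carbon bound to an aromatic carbon. Going by the values given here, no measured step makes a change of this kind; the one measured step, an at least 1.4-fold lower number from compound 1 to compound 2 (0.16 log units; that floor lies within the scatter), replaces a different group altogether and gives no guide to the present substitution. With compound 1 standing only at a limit, the size of any change from it cannot be fixed. Among the compounds with values here, for compound 3 the expected step is an at least 1.4-fold lower number from compound 1 to compound 3 (0.15 log units; that floor lies within the scatter), a loose judgement that rests on no measured analogue. The estimate for compound 3 in this assay is 7000 nM, with a range from 2000 nM to 25000 nM.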

Compound 3, half-maximal inhibitory concentration: > 10000 nM
Compound 3: no number, only a limit (the forecaster's own chance of this, stated with the estimate: 45%); middle value at least 1.4-fold (0.15 log units) away from the limit.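

In this assay compound 3 gives > 10000 nM, which is a limit and not a number, so replacing 2-carboxypiperidin-1-yl with 2-((2-aminoethyl)carbamoyl)piperidin-1-yl on a saturated chain carbon bound to an aromatic carbon did not yield a measurable value. On these data alone, the step between compound 1 and compound 3 cannot be read, and the new group's effect on the acid-bearing compound remains unknown: the limit of > 10000 nM in this assay, at which 2 of the 3 values shown sit. Going by these compounds alone, the one step that can be read is an at least 1.4-fold higher number from compound 2 to compound 3 (0.16 log units; that floor lies within the scatter), and it sets no direction between 3-hydroxypyrrolidin-1-yl and the new group.

The compounds shown leave open how a plain piperidin-1-yl with nothing on the ring, or a 2-carbamoylpiperidin-1-yl without the aminoethyl chain, would read in this assay. Also open, as far as these compounds go, is whether a longer chain ending in an amine, such as 3-aminopropyl on the same carbonyl, would give a real number and so allow a size to be put on a change at this position.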